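The compounds below may be only part of what the source reports. "The series", "measured", "known", "first", "only" and "open" are said of these compounds alone.

Three compounds carry numbers in a functional assay on HL-60 cells (Homo sapiens) for antiproliferative activity, read by sulforhodamine B assay, with a stated time of 72 h (a lower number here means a stronger inhibitor, a higher number a weaker inhibitor), so far. Compound 1, `NC(=S)N/N=C/c1cc2cccnc2s1`, reaches only the limit of the assay and gives > 100000 nM; this is a limit, not a number, and (the limit of > 100000 nM in this assay, at which 1 of the 3 values shown sits). Compound 2, `Cc1ccc(NC(=S)N/N=C/c2ccc3ccccc3n2)cc1`, gives 78300 nM in this assay, the higher of the two numbers measured. Compound 3, `CN(C)C(=S)N/N=C/c1nc2ccccc2s1`, gives 3680 nM in this assay, a lower number than compound 2 by a gap that lies beyond the scatter; the two compounds differ at more than one place, so nothing is read into that gap beyond the two values themselves.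

The step followed here goes from compound 2 to compound 4, `COc1ccc(NC(=S)N/N=C/c2ccc3ccccc3n2)cc1`. The change is methoxy in place of methyl on an aromatic carbon. Going by the values given here, it touches only that one group and leaves the rest of compound 2 unchanged. Among the compounds with values here, no measured pair shows what such a change does, so the expectation rests on the small size of the change alone: in this assay the step from compound 2 to compound 4 is expected to be a 1.3-fold lower number from compound 2 to compound 4 (0.12 log units; within the scatter), none beyond the scatter, in either direction. Compound 4 is therefore estimated at 60000 nM in this assay, with a range from 15000 nM to 250000 nM. A limit-only read-out for compound 4 cannot be excluded.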

Compound 4, half-maximal inhibitory concentration: 43800 nM
The estimate for compound 4 lay 1.4-fold (0.14 log units) above the measured number; measured number inside the range.
By their numbers in this assay, from the lowest: compound 3; then compounds 4 and 2 (each within the scatter of the next). At a limit, above all of these: compound 1.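

In this assay, going by these compounds alone, the first step with a single change reads a 1.8-fold lower number from compound 2 to compound 4 (0.25 log units; within the scatter), for methoxy in place of methyl on an aromatic carbon, para to a large group. At this position, the change from 4-methylphenyl to 4-methoxyphenyl adds one oxygen and one hydrogen-bond acceptor without separating compound 2 from compound 4, and both compounds give numbers, so the step can be read directly. Compound 1 remains the only compound at a limit, and a limit is not a number: the limit of > 100000 nM in this assay, at which 1 of the 4 values shown sits.

This single pair does not show whether a chlorine, an amine or a carboxylic acid in place of the methyl on the same aromatic carbon would produce a step beyond the scatter. It also leaves open whether methoxy in place of methyl would read the same way at another carbon of the six-membered aromatic ring, or on the core of compound 3, which carries a dimethylamino group where compound 2 carries the 4-methylphenyl group.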